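Hydroxymethyl removal on the dioxolane-bearing compound 1

The source may report more compounds than this note shows. Statements on the series, on what has been measured and on what is new or still open speak of the compounds shown alone.

Measured compounds:
compound 1 `CC1(C)O[C@@H](CO)[C@H](Cn2cc(Cn3c4c(c5ccccc53)C(=O)c3c[n+]([O-])c5ccccc5c3C4=O)nn2)O1`: 500 nM
compound 2 `O=C1c2c[n+]([O-])c3ccccc3c2C(=O)c2c1c1ccccc1n2CCCCN1CCCCC1`: 610 nM
compound 3 `CN1CCN(CCCn2c3c(c4ccccc42)C(=O)c2c[n+]([O-])c4ccccc4c2C3=O)CC1`: 230 nM

All numbers come from a toxicity assay on L02 cells (Homo sapiens) for cytotoxicity, read by MTT assay, with a stated time of 72 h; on this read-out lower numbers stand for stronger inhibition and higher numbers for weaker inhibition. Compound 1 stands second highest of the three; compound 2 lies within the scatter of it, while compound 3 sits beyond the scatter with the lower number. Among the compounds with values here, the only single-place step among measured compounds, a 2.7-fold lower number from compound 2 to compound 3 (0.42 log units; beyond the scatter), concerns a saturated chain carbon and not the five-membered non-aromatic ring with 2 oxygen; it does not bear on compound 4 `CC1(C)OC[C@H](Cn2cc(Cn3c4c(c5ccccc53)C(=O)c3c[n+]([O-])c5ccccc5c3C4=O)nn2)O1`. Compound 4 differs from compound 1 by hydrogen in place of hydroxymethyl on a saturated ring carbon. Within the data shown here, no measured step touches this ring, so nothing beyond the scatter is expected in this assay in either direction. Compound 4 is estimated at 500 nM, range 250 nM to 1000 nM. The expected step is no change at the digits printed from compound 1 to compound 4 (within the scatter), within the scatter.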

Compound 4, half-maximal inhibitory concentration: 470 nM
Compound 4: middle estimate off by 1.1-fold (0.03 log units), on the high side; low and high end bracket the measured number.
By their numbers in this assay, from the lowest: compound 3; then compounds 4, 1 and 2 (each within the scatter of the next).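

In this assay, within the data shown here, hydrogen in place of hydroxymethyl on this saturated ring carbon gives [ a 1.1-fold lower number from compound 1 to compound 4 (0.03 log units; within the scatter) ], the first measured step on the five-membered non-aromatic ring with 2 oxygen. The hydroxymethyl, with its hydrogen-bond donor and acceptor, can therefore leave this position without a change beyond the scatter in this read-out. No supporting data explain this result.

As far as these compounds go, whether an amine, a carboxylic acid or a longer chain at this ring carbon would shift the number remains open. So does whether the two methyl groups on the ring can be replaced by hydrogen with a similar result.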